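The source may report more compounds than this note shows. Statements on the series, on what has been measured and on what is new or still open speak of the compounds shown alone.

Among the compounds with values here, compound 2 `C=C(Br)C(=O)Nc1cccc(-c2cn3nc(Cc4ccc(Cl)cc4)sc3n2)c1` gives 2700 nM in a functional assay on HeLa cells (Homo sapiens) for inhibition, read by cell counting, with a stated time of 4 days (on this read-out higher numbers stand for weaker inhibition and lower numbers for stronger inhibition), the highest of the two numbers so far; compound 1 `C=C(Br)C(=O)Nc1cccc(-c2cn3nc(-c4cccs4)sc3n2)c1` gives 670 nM. Within the data shown here, the only measured step, a 4.0-fold higher number from compound 1 to compound 2 (0.61 log units; beyond the scatter), exchanged thiophen-2-yl for 4-chlorobenzyl. Compound 3 `C=C(Br)C(=O)Nc1cccc(-c2cn3nc(-c4ccc(OC)cc4)sc3n2)c1` differs from compound 2 by 4-methoxyphenyl in place of 4-chlorobenzyl on an aromatic carbon, which returns to an aromatic ring bound directly to the core, as in compound 1, though with a different ring. The step from compound 1 to compound 2 bears only loosely, since both the ring and the attachment changed there. A lower number than compound 2 is expected for compound 3, with the step estimated as a 2.7-fold lower number from compound 2 to compound 3 (0.43 log units; beyond the scatter). Compound 3 is estimated at 1000 nM, range 350 nM to 3000 nM.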

Compound 3, half-maximal inhibitory concentration: 2300 nM
Estimate against measurement, compound 3: 2.3-fold (0.36 log units) below; measured number inside the range.
By their numbers in this assay, from the lowest: compound 1; then compounds 3 and 2 (each within the scatter of the next).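

In this assay, the exchange at this position gives a 1.2-fold lower number from compound 2 to compound 3 (0.07 log units; within the scatter), so 4-methoxyphenyl, bound directly to the core, and 4-chlorobenzyl read alike here. A directly bound ring is therefore not enough on its own to reach the level of compound 1, as shown by a 3.4-fold higher number from compound 1 to compound 3 (0.54 log units; beyond the scatter). No measurement available here explains this difference. Still open, from the compounds shown here alone, is whether the thiophen-2-yl result extends to other five-membered rings, such as furan-2-yl, and how unsubstituted phenyl or an amine such as morpholine would read on this carbon.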